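From 4-Bromophenyl to Phenethyl on the Sulfur

The compounds below may be only part of what the source reports. "The series", "measured", "known", "first", "only" and "open" are said of these compounds alone.

Within the data shown here, in a functional assay on SMMC-7721 cells (Homo sapiens) for inhibition, read by CCK-8 assay, with a stated time of 72 h, tested at 2 uM (on this read-out lower numbers stand for less inhibition of growth and higher numbers for more inhibition of growth at the one concentration tested), compound 2 `Nc1ccccc1NC(=O)c1ccc(CSc2ccc(Br)cc2)cc1` gives 10%, the lower of the two numbers so far, while compound 1 `CCc1ccc(SCc2ccc(C(=O)Nc3ccccc3N)cc2)cc1` gives 25.7%. The next compound, compound 3 `Nc1ccccc1NC(=O)c1ccc(CSCCc2ccccc2)cc1`, has phenethyl in place of 4-bromophenyl on a sulfur. Among the measured compounds shown here, only one measured step bears on this change, and only indirectly. This is the modest step of a number 15.7 percentage points lower from compound 1 to compound 2 (beyond the scatter), with bromo in place of ethyl on an aromatic carbon. For the measured compounds named here, no measured step replaces the whole group on the sulfur, so the evidence is thin. Compound 3 also loses the bromine, and compound 1, which has none, stands higher at 25.7%, so a small rise in this assay is expected. The expected change is a number 10 percentage points higher from compound 2 to compound 3 (within the scatter), and it may not exceed the scatter. For compound 3 the estimated value is 20%, with an expected range of 5% to 40%.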

Compound 3, percent growth inhibition at one concentration: 28.1%
For compound 3 the middle estimate is 8.1 percentage points below the measured one, within the range that was stated.
By their numbers in this assay, from the lowest: compound 2; then compounds 1 and 3 (each within the scatter of the next).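

In this assay, the group on the sulfur can be replaced as a whole, and the step of a number 18.1 percentage points higher from compound 2 to compound 3 (beyond the scatter) shows that phenethyl in place of 4-bromophenyl changes the number beyond the scatter. The step of a number 2.4 percentage points higher from compound 1 to compound 3 (within the scatter) lies within the scatter, so this assay does not separate phenethyl from 4-ethylphenyl at this position. Among these three compounds, only the 4-bromophenyl group of compound 2 stands apart, and no measurement shown accounts for this.

The compounds shown leave open whether a plain phenyl, a longer chain or a chain ending in an amine or a carboxylic acid on the sulfur would keep the number at this level. They also leave open how these groups would compare at other concentrations.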